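The compounds below may be only part of what the source reports. "The series", "measured", "known", "first", "only" and "open" are said of these compounds alone.

In a functional assay on SGC-7901 cells (Homo sapiens) for antiproliferative activity, read by MTT assay, with a stated time of 24 h (on this read-out lower numbers stand for stronger inhibition and higher numbers for weaker inhibition), compound 1 `Cc1cccc(-n2cc(-c3ccccc3NS(=O)(=O)c3c[nH]c(=O)[nH]c3=O)nn2)c1` gives 3510 nM, and compound 2 `Cc1ccc(-n2cc(-c3ccccc3NS(=O)(=O)c3c[nH]c(=O)[nH]c3=O)nn2)cc1` gives 6390 nM. The two differ by 4-methylphenyl in place of 3-methylphenyl on an aromatic nitrogen, a step of a 1.8-fold higher number from compound 1 to compound 2 (0.26 log units; within the scatter). Compound 3 `Cc1cccc(-n2cc(-c3ccc(NS(=O)(=O)c4c[nH]c(=O)[nH]c4=O)cc3)nn2)c1` stands on a different core; how its core differs from that of compound 1 is not broken down here. In this assay compound 3 gives 17500 nM, the highest of the three numbers, beyond the scatter from both compound 1 and compound 2. Compound 4 `Cc1ccc(-n2cc(-c3ccc(NS(=O)(=O)c4c[nH]c(=O)[nH]c4=O)cc3)nn2)cc1` has not yet been measured. It differs from compound 3 by 4-methylphenyl in place of 3-methylphenyl on an aromatic nitrogen, the same change that occurs twice among these compounds. Because that change gave a 1.8-fold higher number from compound 1 to compound 2 (0.26 log units; within the scatter), a step inside the scatter, a similar step of a 1.6-fold higher number from compound 3 to compound 4 (0.20 log units; within the scatter) is expected here. Compound 4 is therefore estimated at 28000 nM, within a range from 12000 nM to 70000 nM.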

Compound 4, half-maximal inhibitory concentration: 8350 nM
For compound 4 the middle estimate is 3.4-fold (0.53 log units) above the measured one; measured number below the stated range.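

In this assay the move from 3-methylphenyl to 4-methylphenyl gives a 2.1-fold lower number from compound 3 to compound 4 (0.32 log units; beyond the scatter), a modest step. Set beside the earlier step, the same change did not carry over from one core to the other: the same change on two cores in this assay, a 1.8-fold higher number (0.26 log units; within the scatter) from compound 1 to compound 2 and a 2.1-fold lower number (0.32 log units; beyond the scatter) from compound 3 to compound 4, 3.8-fold (0.58 log units) apart, beyond the scatter of two such steps. This shows that, for these two pairs, the outcome of the change depends on the core it stands on, but it does not show why, or how the change would behave on any further core.

Going by these compounds, only 3-methylphenyl and 4-methylphenyl stand on the aromatic nitrogen here, so it remains open whether a plain phenyl, a chlorophenyl or a methoxyphenyl group would shift with the core in the same way. Also open, on these data alone, is whether this reversal appears in any other cells.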